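Methyl on the Amide Nitrogen: Estimating Compound 4

A few compounds are considered here, and "the series" means these few. Any claim that something is new, unique, unknown or untested is made for them only; others in the source may bear on it.

Compound 1 `C#CCN(Cc1ccc2nc(C)nc(O)c2c1)c1ccc(C(=O)N[C@@H](CCC(=O)O)C(=O)N[C@@H](CCC(=O)O)C(=O)O)cc1` was tested in a functional assay for inhibition, with Mus musculus as the target (on this read-out lower numbers stand for stronger inhibition and higher numbers for weaker inhibition), where compound 1 gives 2700 nM, the second highest of the three numbers recorded. Its nearest neighbour is compound 2 `C#CCN(Cc1ccc2nc(C)nc(O)c2c1)c1ccc(C(=O)N[C@@H](CC(C)C(=O)O)C(=O)N[C@@H](CCC(=O)O)C(=O)O)cc1`, which in this assay gives 3400 nM; the step of a 1.3-fold higher number from compound 1 to compound 2 (0.10 log units; within the scatter). Compound 3 `C#CCN(Cc1ccc2nc(C)nc(O)c2c1)c1ccc(C(=O)N[C@@H](CC(C)(C)C(=O)O)C(=O)N[C@@H](CCC(=O)O)C(=O)O)cc1` gives 1200 nM in this assay, and the step of a 2.3-fold lower number from compound 1 to compound 3 (0.35 log units; beyond the scatter), while a 2.8-fold lower number from compound 2 to compound 3 (0.45 log units; beyond the scatter).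

Compound 4 `C#CCN(Cc1ccc2nc(C)nc(O)c2c1)c1ccc(C(=O)N[C@@H](CCC(=O)O)C(=O)N(C)[C@@H](CCC(=O)O)C(=O)O)cc1` differs from compound 1 by methyl in place of hydrogen on an amide-type nitrogen. Among the measured compounds shown here, none of the measured steps places a methyl on an amide-type nitrogen; all three concern methyl groups on saturated chain carbons, so they bear on the new change only loosely. They show that adding a single methyl in this region moves the number by at most a modest amount in either direction. For compound 4 in this assay the estimate is 4000 nM, with a range from 1500 nM to 12000 nM. The expected step of a 1.5-fold higher number from compound 1 to compound 4 (0.17 log units; within the scatter) is estimated to lie near the scatter, leaning toward a higher number.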

Compound 4, half-maximal inhibitory concentration: 2200 nM
Beside the measured number, compound 4's estimate is 1.8-fold (0.26 log units) above it, within the range that was stated.
By their numbers in this assay, from the lowest: compounds 3, 4, 1 and 2 (each within the scatter of the next, the first and the last beyond it).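

In this assay, methyl in place of hydrogen on an amide-type nitrogen gives a 1.2-fold lower number from compound 1 to compound 4 (0.09 log units; within the scatter), so compound 1 and compound 4 cannot be told apart at this read-out. This is the first step shown at this nitrogen, whose other neighbours are a carbonyl carbon and a saturated chain carbon, as the earlier steps all concern saturated chain carbons; here the amide hydrogen can give way to methyl with no difference beyond the scatter. Nothing available explains this result.

The compounds shown leave open whether an ethyl group or a longer chain on this nitrogen would read the same way. They also leave open whether methyl on this nitrogen would combine with the 1-carboxy-1-methylethyl group of compound 3 without a difference beyond the scatter.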